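The compounds below may be only part of what the source reports. "The series", "measured", "known", "first", "only" and "open" are said of these compounds alone.

Of the compounds shown here, three from this series have been tested in a functional assay on SK-MEL-5 cells (Homo sapiens) for inhibition, read by sulforhodamine B assay, with a stated time of 48 h; on this read-out lower numbers stand for higher toxicity in this test and higher numbers for lower toxicity in this test. Compound 1, `CCOC(=O)[C@H](CCC(=O)O)NC(=O)c1ccc(Sc2nc3cc(N)cc(N)c3nc2-c2ccccc2)cc1`, gives 85100 nM. Compound 2, `Nc1cc(N)c2nc(-c3ccccc3)c(Sc3ccc(F)cc3)nc2c1`, gives 70800 nM. Compound 3, `CCOC(=O)[C@H](CCC(=O)O)NC(=O)c1ccc(CNc2nc3cc(N)cc(N)c3nc2-c2ccccc2)cc1`, is reported only as a limit of this assay, < 100000 nM, not as a number (the limit of < 100000 nM in this assay, at which 1 of the 3 values shown sits). Among the two actual numbers, compound 2 and compound 1 sit within the usual scatter of each other, so neither can be called more or less toxic than the other on these data.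

Compound 4, `Nc1cc(N)c2nc(-c3ccccc3)c(NCc3ccc(F)cc3)nc2c1`, has not yet been measured. It differs from compound 2 in one place: (4-fluorobenzyl)amino in place of (4-fluorophenyl)sulfanyl on an aromatic carbon. The same kind of exchange separates compound 1 from compound 3, where compound 1 has a number and compound 3 only a limit, so those two values do not show a clear shift. On that basis the step from compound 2 to compound 4 is expected to stay within the scatter, giving a 1.1-fold higher number from compound 2 to compound 4 (0.05 log units; within the scatter). Compound 4 is therefore estimated at 80000 nM in this assay, with a range from 35000 nM to 180000 nM.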

Compound 4, concentration lethal to 50% of the cells: 6920 nM
Estimate against measurement, compound 4: 12-fold (1.06 log units) above; the measured number lies below the stated range.
By their numbers in this assay, from the lowest: compound 4; then compounds 2 and 1 (each within the scatter of the next).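

In this assay, this position on an aromatic carbon of the shared core proves sensitive to what is attached there: (4-fluorobenzyl)amino in place of (4-fluorophenyl)sulfanyl gives a 10-fold lower number from compound 2 to compound 4 (1.01 log units; beyond the scatter). For the compounds shown here, this is the first step that can be read and the first to lie beyond the scatter, so the exchange clearly matters when the rest of the molecule stays the same. Compound 3 is reported only as a limit, so the same exchange from compound 1 to compound 3 cannot be read and gives no second example: the limit of < 100000 nM in this assay, at which 1 of the 4 values shown sits.

The exchange alters the connecting atom and the length of the connection together, so the compounds shown cannot say which of these matters. A (4-fluorophenyl)amino group or a (4-fluorobenzyl)sulfanyl group at this position would separate the two.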